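A few compounds are considered here, and "the series" means these few. Any claim that something is new, unique, unknown or untested is made for them only; others in the source may bear on it.

The series shares a hydroxamic acid tail linked through a chain to a piperidine that carries an aryl sulfonyl group, and the aryl part is where the compounds differ. Going by the values given here, compound 1 `Cc1cc(S(=O)(=O)N2CCC(CCCC(=O)NO)CC2)cc2ccccc12` is the only member with a number: in a functional assay on HCT-116 cells (Homo sapiens) for inhibition, read by resazurin assay, with a stated time of 5 days (on this read-out higher numbers stand for weaker inhibition of growth and lower numbers for stronger inhibition of growth), compound 1 gives 17300 nM, so its inhibition of growth is weak. Compound 2 `O=C(CCCC1CCN(S(=O)(=O)c2ccccc2C(F)(F)F)CC1)NO` has no number; in this assay compound 2 gives "not determined" (no result reported). Compound 3 `O=C(CCCC1CCN(S(=O)(=O)c2ccc3ncsc3c2)CC1)NO` likewise stands without a result, and in this assay compound 3 gives "not determined" (no result reported). Among the compounds with values here, compound 2 therefore cannot be placed on the scale at all, and there is no measured step in the set to lean on.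

Compound 4 `O=C(CCCC1CCN(S(=O)(=O)c2ccccc2Cl)CC1)NO` is the compound now awaiting measurement. It differs from compound 2 by chloro in place of trifluoromethyl on an aromatic carbon, a change confined to a single group on an aromatic carbon of a six-membered aromatic ring of carbon only. Since compound 2 has no value, the size and direction of this step in this assay cannot be taken from a measured pair; the account can only note that the one measured relative, compound 1, lies in the weak range.

On that basis compound 4 is expected to inhibit growth weakly, with an estimated value of 15000 nM and a range from 4000 nM to 60000 nM.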

Compound 4, concentration for 50% growth inhibition: 2800 nM
For compound 4 the middle estimate is 5.4-fold (0.73 log units) above the measured one; measured number below the stated range.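

In this assay compound 4 gives 2800 nM but compound 2 has no number, so the exchange of trifluoromethyl for chloro between compound 2 and compound 4 cannot be read as a step. No supporting data bear on this result. The compounds shown leave open whether chloro or trifluoromethyl gives the stronger inhibition of growth.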